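A larger swap on the shared core of compound 3

The source may hold more compounds than are shown below. What is called first, only, known or untested is meant among the compounds shown, and "the series" means these compounds.

In a functional assay on MCF7 cells (Homo sapiens) for inhibition, with a stated time of 72 h (on this read-out lower numbers stand for stronger inhibition and higher numbers for weaker inhibition), three compounds share one core and differ in a single aromatic group. Compound 1 `NC1CCC(Nc2nc(NCc3ccc(-c4ccccc4)nc3)c3ncn(C4CCCC4)c3n2)CC1`, carrying phenyl, gives 483 nM. Compound 2 `NC1CCC(Nc2nc(NCc3ccc(-c4ccco4)nc3)c3ncn(C4CCCC4)c3n2)CC1`, carrying furan-2-yl, gives 33 nM. Compound 3 `NC1CCC(Nc2nc(NCc3ccc(-c4cccs4)nc3)c3ncn(C4CCCC4)c3n2)CC1`, carrying thiophen-2-yl, gives 92 nM, the middle value of the three.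

Compound 4 `NC1CCC(Nc2nc(NCc3cc(Cl)ccc3O)c3ncn(C4CCCC4)c3n2)CC1` has 5-chloro-2-hydroxyphenyl in place of 6-(thiophen-2-yl)pyridin-3-yl on a saturated chain carbon bound to a nitrogen on an aromatic ring.

Within the data shown here, three measured steps bear on this change. The large one runs a 15-fold lower number from compound 1 to compound 2 (1.17 log units; beyond the scatter), and the modest ones run a 5.3-fold lower number from compound 1 to compound 3 (0.72 log units; beyond the scatter) and a 2.8-fold higher number from compound 2 to compound 3 (0.45 log units; beyond the scatter). Among the measured compounds shown here, each exchanges only one ring, so even small swaps here move the number beyond the scatter. None of them replaces the whole 6-(thiophen-2-yl)pyridin-3-yl group, so they guide the size only loosely and leave the direction a cautious guess.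

The expected change is an 8.7-fold higher number from compound 3 to compound 4 (0.94 log units; beyond the scatter), toward weaker inhibition. The estimate for compound 4 is 800 nM, with an expected range of 150 nM to 4000 nM.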

Compound 4, half-maximal inhibitory concentration: 430 nM
The estimate for compound 4 lay 1.9-fold (0.27 log units) above the measured number; low and high end bracket the measured number.
By their numbers in this assay, from the lowest: compound 2; then compound 3; then compounds 4 and 1 (each within the scatter of the next).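

Exchanging the whole two-ring group for the single ring of 5-chloro-2-hydroxyphenyl keeps a measurable effect in this assay, though it gives a 4.7-fold higher number from compound 3 to compound 4 (0.67 log units; beyond the scatter) and a 13-fold higher number from compound 2 to compound 4 (1.11 log units; beyond the scatter), so the gains seen with thiophen-2-yl and furan-2-yl do not carry over to this group. Against the phenyl-bearing group, the exchange gives a 1.1-fold lower number from compound 1 to compound 4 (0.05 log units; within the scatter), which means two quite different groups at this place cannot be told apart here. Nothing available gives a reason for these steps.

Going by these compounds, the new group differs from the old ones in several ways at once, so the share of the chlorine, the hydroxyl and the loss of the ring nitrogen stays open. On these data alone, how the same ring would behave with an amine or a carboxylic acid in place of the hydroxyl also remains unknown.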